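A few compounds are considered here, and "the series" means these few. Any claim that something is new, unique, unknown or untested is made for them only; others in the source may bear on it.

Among the compounds measured in a functional assay on MDA-MB-231 cells (Homo sapiens) for antiproliferative activity, read by MTT assay, with a stated time of 48 h (a higher number here means a weaker inhibitor, a lower number a stronger inhibitor), compound 3 `O=C(Nc1cc(Sc2ncnc3nc[nH]c23)c(O)c2ccccc12)c1ccc(Cl)cc1` gives 23000 nM, the only number in this set. Compound 1 `O=C(Nc1cc(Sc2ncn[nH]2)c(O)c2ccccc12)c1ccc([N+](=O)[O-])cc1` gives > 100000 nM, which is a limit of the assay. Compound 2 `Cc1nnc(Sc2cc(NC(=O)c3ccc(Cl)cc3)c3ccccc3c2O)s1` also gives > 100000 nM, again a limit. For the measured compounds named here, the one step that can be read, an at least 4.3-fold lower number from compound 2 to compound 3 (0.63 log units; beyond the scatter), starts from the limit described by the limit of > 100000 nM in this assay, at which 2 of the 3 values shown sit, and so is known only as a minimum. Compound 4 `O=C(Nc1cc(Sc2ncnc3nc[nH]c23)c(O)c2ccccc12)c1ccc([N+](=O)[O-])cc1` differs from compound 3 by nitro in place of chloro on an aromatic carbon. Going by the values given here, no measured step bears directly on this exchange: compound 1 carries the nitro group but also a different sulfur substituent, and its value is a limit, so it cannot be compared with compound 3 as a single change. With nothing to point to a change beyond the scatter, compound 4 is expected to show a step of a 1.3-fold higher number from compound 3 to compound 4 (0.12 log units; within the scatter). The estimate for compound 4 in this assay is 30000 nM, with a range from 10000 nM to 100000 nM.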

Compound 4, half-maximal inhibitory concentration: > 100000 nM
Compound 4 ended at the assay's limit; the forecaster's own chance of this, stated with the estimate: 25%; middle value at least 3.3-fold (0.52 log units) away from the limit.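

In this assay, for the compounds shown here, nitro in place of chloro para to a large group gives the first readable step at this position, an at least 4.3-fold higher number from compound 3 to compound 4 (0.63 log units; beyond the scatter), with the group on the sulfur held the same. Of this pair, only the chloro compound, compound 3, gives a number, and the step's full size stays unknown because compound 4 sits at a limit of the assay: the limit of > 100000 nM in this assay, at which 3 of the 4 values shown sit.
The step from compound 1 to compound 4 cannot be read, as both of its ends are limits.

The compounds shown leave open whether a measurable number at this position is special to chloro or would also appear with bromo, methoxy or an amine in its place. They also leave open how far above the limit compound 4 lies, and so the true size of this exchange.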